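A 3-bromophenyl step from compound 2

The source may report more compounds than this note shows. Statements on the series, on what has been measured and on what is new or still open speak of the compounds shown alone.

Compound 1 `COc1ccc(-c2cnc(NC(=O)C3CCOCC3)n2C)cc1`: > 100000 nM, a limit
Compound 2 `COc1ccc(-c2cnc(NC(=O)c3ccn[nH]3)n2C)cc1`: > 100000 nM, a limit

In a toxicity assay on THP-1 cells (Homo sapiens) for inhibition (a higher number here means that more compound is tolerated, a lower number that less compound is tolerated), compound 2 stands at > 100000 nM, which is a limit and not a number. Going by the values given here, the only measured step is a step that the two limits leave unreadable from compound 1 to compound 2, so it offers no size to carry forward. Compound 1 and compound 2 share (the limit of > 100000 nM in this assay, at which 2 of the 2 values shown sit). Compound 3 `COc1ccc(-c2cnc(NC(=O)c3cccc(Br)c3)n2C)cc1` carries the change (3-bromophenyl in place of 1H-pyrazol-5-yl on a carbonyl carbon). With no readable step, only a small downward move in this assay is expected, or none, and a limit may be reported again. For compound 3 the estimated value is 70000 nM, within an expected range of 25000 nM to 150000 nM. This estimate means an expected at least 1.4-fold lower number from compound 2 to compound 3 (0.15 log units; that floor lies within the scatter).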

Compound 3, half-maximal cytotoxic concentration: > 100000 nM
Compound 3 gave a limit, no number; the forecaster's own chance of this, stated with the estimate: 60%; at least 1.4-fold (0.15 log units) between middle value and limit.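

No step among compound 1, compound 2 and compound 3 can be read in this assay, and all three share a single limit: the limit of > 100000 nM in this assay, at which 3 of the 3 values shown sit.

The compounds shown leave open whether oxan-4-yl, 1H-pyrazol-5-yl and 3-bromophenyl on the carbonyl carbon differ at all in half-maximal cytotoxic concentration.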